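The source may hold more compounds than are shown below. What is called first, only, known or untested is meant among the compounds shown, and "the series" means these compounds.

Measured in a functional assay on MCF7 cells (Homo sapiens) for inhibition, read by MTT assay, with a stated time of 72 h; on this read-out higher numbers stand for weaker inhibition and lower numbers for stronger inhibition:
- compound 1 `COc1cc(NC(C)CCCNC(=O)NNC(=O)Nc2ccc(Br)cc2)c2ncccc2c1`: 100 nM
- compound 2 `COc1cc(NC(C)CCCNC(=O)Nc2cc(C(F)(F)F)cc(C(F)(F)F)c2)c2ncccc2c1`: 1600 nM

Of these two numbers, compound 2 holds the higher, beyond the scatter from compound 1. Compound 3 `COc1cc(NC(C)CCCNC(=O)Nc2cccc(C(F)(F)F)c2)c2ncccc2c1` carries hydrogen in place of trifluoromethyl on an aromatic carbon. Among the compounds with values here, no measured pair isolates this change, so the expectation is a judgement: a small step in this assay towards a higher number, near the edge of the scatter. The expected change is a 1.9-fold higher number from compound 2 to compound 3 (0.27 log units; within the scatter). Compound 3 is estimated at 3000 nM, with an expected range of 1000 nM to 12000 nM.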

Compound 3, half-maximal inhibitory concentration: 3300 nM
For compound 3 the middle estimate is 1.1-fold (0.04 log units) below the measured one; the measured number falls inside the stated range.
By their numbers in this assay, from the lowest: compound 1; then compound 2; then compound 3.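

In this assay, hydrogen in place of trifluoromethyl on this aromatic carbon gives a 2.1-fold higher number from compound 2 to compound 3 (0.31 log units; beyond the scatter), a modest step that shows this position has a measurable but limited effect on the number. The exchange of ((4-bromophenyl)carbamoyl)amino for 3-(trifluoromethyl)phenyl on the amide-type nitrogen weighs far more, with a 33-fold higher number from compound 1 to compound 3 (1.52 log units; beyond the scatter). No available data account for either step. Still open, as far as these compounds go, is how a nitrile or a methoxy group on this aromatic carbon would compare with trifluoromethyl and hydrogen. Also open, from the compounds shown here alone, is what hydrogen in place of the remaining trifluoromethyl would give.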